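Adding a Fluorine: Expected Effect on Cell Toxicity

A few compounds are considered here, and "the series" means these few. Any claim that something is new, unique, unknown or untested is made for them only; others in the source may bear on it.

Within the data shown here, compound 3 `N/C(=N/NC(CC(=O)c1ccc(-n2ccnc2)cc1)c1ccccc1)c1ccccn1` gives 63500 nM in an ADME assay on Vero cells (Chlorocebus sabaeus) for cytotoxicity, read by MTT assay, with a stated time of 72 h (on this read-out higher numbers stand for lower toxicity in this test and lower numbers for higher toxicity in this test), the highest of the three numbers measured so far. Compound 2 `N/C(=N/NC(CC(=O)c1ccc(-n2ccnc2)cc1)c1cccc(Br)c1)c1ccccn1` gives 51300 nM and compound 1 `N/C(=N/NC(CC(=O)c1ccc(-n2ccnc2)cc1)c1ccc(Cl)cc1Cl)c1ccccn1` gives 27800 nM in this assay. The step of a 1.2-fold higher number from compound 2 to compound 3 (0.09 log units; within the scatter) stays within the scatter, while the step of a 2.3-fold higher number from compound 1 to compound 3 (0.36 log units; beyond the scatter) is modest but beyond it, so the unsubstituted phenyl of compound 3 stands only a little apart from its halogenated relatives.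

Compound 4 `N/C(=N/NC(CC(=O)c1ccc(-n2ccnc2)cc1)c1cccc(F)c1)c1ccccn1` is compound 3 with a single change: fluoro in place of hydrogen on an aromatic carbon. The step that bears most directly on this is a 1.2-fold higher number from compound 2 to compound 3 (0.09 log units; within the scatter), in which hydrogen in place of bromo on an aromatic carbon produced nothing beyond the scatter. The larger step of a 2.3-fold higher number from compound 1 to compound 3 (0.36 log units; beyond the scatter) involved two chlorines and so speaks less directly to one fluorine. The expectation for compound 4 is therefore a step of a 1.2-fold lower number from compound 3 to compound 4 (0.06 log units; within the scatter), within the scatter, leaning if anything toward a slightly lower number. Compound 4 is expected to give about 55000 nM, with a range from 30000 nM to 95000 nM.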

Compound 4, half-maximal cytotoxic concentration: 26500 nM
Compound 4: the middle estimate sits 2.1-fold (0.32 log units) above what was measured; measured number below the stated range.
By their numbers in this assay, from the lowest: compounds 4, 1, 2 and 3 (each within the scatter of the next, the first and the last beyond it).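

In this assay the change from phenyl to 3-fluorophenyl gives a 2.4-fold lower number from compound 3 to compound 4 (0.38 log units; beyond the scatter), so one added heavy atom on this ring is enough to move the number, toward higher toxicity in this test. The 3-bromophenyl of compound 2 did not separate from compound 3 in this way, yet a 1.9-fold lower number from compound 2 to compound 4 (0.29 log units; within the scatter), so compound 2 and compound 4 cannot be told apart and the two halogens cannot be ranked. Likewise a 1.0-fold lower number from compound 1 to compound 4 (0.02 log units; within the scatter), which leaves the single fluoro level with the 2,4-dichlorophenyl of compound 1.

Nothing at hand says why this one fluoro shifts the number. Also open, from the compounds shown here alone, is whether a methyl, a methoxy or an amine on this same aromatic carbon, or a fluoro on another carbon of the ring, would behave the same way.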